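The compounds below may be only part of what the source reports. "The series", "measured", "known", "first", "only" and "open" are said of these compounds alone.

Working notes on the series. Compound 1 `COc1nc(-c2cc3ccccc3o2)cc(-c2ccc(Cl)cc2)c1C#N`, compound 2 `COc1nc(-c2cc3ccccc3o2)cc(-c2ccc(Cl)cc2Cl)c1C#N` and compound 3 `COc1nc(-c2cc3ccccc3o2)cc(-c2ccc(F)cc2)c1C#N` share one core and differ in one place each. In a functional assay on aorta (strain Wistar) for inhibition, with Thoracic aorta (Rattus norvegicus) as the target (a lower number here means a stronger inhibitor, a higher number a weaker inhibitor), compound 1 gives 286000 nM. In this assay compound 2 gives 322000 nM, and compound 3 gives 321000 nM. Compound 3 therefore stands second highest of the three numbers, with compound 2 nearest and compound 1 furthest, both within the scatter. The steps observed so far are a 1.1-fold higher number from compound 1 to compound 2 (0.05 log units; within the scatter), a 1.1-fold higher number from compound 1 to compound 3 (0.05 log units; within the scatter) and a 1.0-fold lower number from compound 2 to compound 3 (0.00 log units; within the scatter); none of them moves the number beyond the scatter.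

Compound 4 `COc1nc(-c2cc3ccccc3o2)cc(-c2ccc(C)cc2)c1C#N` has not yet been measured. It differs from compound 3 by methyl in place of fluoro on an aromatic carbon. The three measured steps bear on this change only in a general way: each exchange of a group on this ring, whether chloro for hydrogen or fluoro for chloro, left the number within the scatter. The change to compound 4 is therefore expected to behave alike, with a step of a 1.0-fold lower number from compound 3 to compound 4 (0.00 log units; within the scatter), not beyond the scatter in either direction. On this basis compound 4 is expected to give about 320000 nM in this assay, with a range from 160000 nM to 640000 nM.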

Compound 4, half-maximal inhibitory concentration: 266000 nM
The estimate for compound 4 lay 1.2-fold (0.08 log units) above the measured number, and the stated range covers the measured number.
By their numbers in this assay, from the lowest: compounds 4, 1, 3 and 2 (each within the scatter of the next).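

In this assay, among these compounds, the earlier compounds carried only halogens at this place on the ring, and methyl is the first carbon group there: it gives a 1.2-fold lower number from compound 3 to compound 4 (0.08 log units; within the scatter). The result is the same when compound 4 is set against the chloro and dichloro compounds, with a 1.1-fold lower number from compound 1 to compound 4 (0.03 log units; within the scatter) and a 1.2-fold lower number from compound 2 to compound 4 (0.08 log units; within the scatter), so all four compounds now lie within the scatter of one another and none of the exchanges among fluoro, chloro and methyl separates them at this position. Nothing at hand gives a reason for this flat response to these groups.

The compounds shown leave open whether any group at this place can move the number beyond the scatter, for instance an amine, a carboxylic acid or a longer chain such as butyl. They also leave open whether the number answers to any change elsewhere on the shared core, such as an amine in place of the methoxy group or a carboxylic acid in place of the nitrile, because every difference here lies on the same phenyl ring.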